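Methyl on the triazole phenyl: compound 3 to compound 4

The source may report more compounds than this note shows. Statements on the series, on what has been measured and on what is new or still open speak of the compounds shown alone.

Working notes on the series built on the shared core of compound 1 `COc1cc2c(Oc3ccc(NC(=O)c4cn(-c5ccccc5)nn4)cc3F)ccnc2cc1OCCCN1CCCCC1`. In a functional assay on NCI-H460 cells (Homo sapiens) for cytotoxicity, read by MTT assay, with a stated time of 72 h (a higher number here means a weaker inhibitor, a lower number a stronger inhibitor), compound 1 gives 210 nM, compound 2 `COc1cc2c(Oc3ccc(NC(=O)c4cn(-c5ccccc5C)nn4)cc3F)ccnc2cc1OCCCN1CCC(C)CC1` gives 2730 nM, and compound 3 `COc1cc2c(Oc3ccc(NC(=O)c4cn(-c5ccccc5)nn4)cc3F)ccnc2cc1OCCCN1CCN(C)CC1` gives 200 nM. Compound 3 carries the lowest number of the three, but the step of a 1.1-fold lower number from compound 1 to compound 3 (0.02 log units; within the scatter) shows that compound 1 and compound 3 cannot be separated; only compound 2 sits clearly apart.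

The next compound, compound 4 `COc1cc2c(Oc3ccc(NC(=O)c4cn(-c5ccccc5C)nn4)cc3F)ccnc2cc1OCCCN1CCN(C)CC1`, differs from compound 3 by methyl in place of hydrogen on an aromatic carbon, ortho to a large group. For the measured compounds named here, no single measured step isolates this change. Going by the values given here, the only related comparison is compound 2 against compound 1: compound 2 carries the same methyl on the phenyl ring together with a second change on the amine, and since the amine swap in the step from compound 1 to compound 3 was within the scatter, the larger part of the gap between compound 1 and compound 2 plausibly falls to the methyl.

Compound 4 is therefore expected to give a higher number, with an estimated step of a 7.5-fold higher number from compound 3 to compound 4 (0.88 log units; beyond the scatter). The estimate for compound 4 in this assay is 1500 nM, within 400 nM to 5000 nM.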

Compound 4, half-maximal inhibitory concentration: 3650 nM
For compound 4 the middle estimate is 2.4-fold (0.39 log units) below the measured one; the range from low to high includes it.
By their numbers in this assay, from the lowest: compounds 3 and 1 (each within the scatter of the next); then compounds 2 and 4 (each within the scatter of the next).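

In this assay, the methyl in place of hydrogen on an aromatic carbon, ortho to a large group, now stands as a single change, with an 18-fold higher number from compound 3 to compound 4 (1.26 log units; beyond the scatter). Phenyl to 2-methylphenyl is thus a large loss on its own, while the amine change read with the methyl present, a 1.3-fold higher number from compound 2 to compound 4 (0.13 log units; within the scatter), leaves 4-methylpiperazin-1-yl and 4-methylpiperidin-1-yl inseparable, which fits the small amine step on the unsubstituted phenyl, a 1.1-fold lower number from compound 1 to compound 3 (0.02 log units; within the scatter). No supporting measurement bears on the origin of this loss.

Open, going by these compounds, is whether a chlorine or a methoxy on the same aromatic carbon gives a similar step, and whether a methyl on another carbon of that phenyl ring does. Also open, on these data alone, is how a morpholine at the chain end would read against these amines.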